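This account rests on a few compounds, and the source may have more. Where it says the series, first, only, none or still open, it means among the compounds named here.

Compounds 1 to 4 share one core and differ only in the group on a double-bonded chain carbon bound to an aromatic carbon and a double-bonded chain carbon. In a functional assay on MCF7 cells (Homo sapiens) for cytotoxicity, read by CellTiter-Glo, with a stated time of 5 days (on this read-out lower numbers stand for stronger inhibition and higher numbers for weaker inhibition), compound 1 (`CC/C(=C(/c1ccc(/C=C/C(=O)O)cc1)c1ccc(O)nc1)c1ccccc1`) stands as "not determined" (no result reported) and offers no guide. Compound 2 (`CC/C(=C(/c1ccc(/C=C/C(=O)O)cc1)c1ccc2[nH]c(=O)oc2c1)c1ccccc1`) gives 56 nM and compound 3 (`CC/C(=C(/c1ccc(/C=C/C(=O)O)cc1)c1ccc2[nH]ccc2c1)c1ccccc1`) gives 9 nM as the lower of the two numbers available. Compound 4 (`CC/C(=C(/c1ccc(/C=C/C(=O)O)cc1)c1ccc2[nH]cnc2c1)c1ccccc1`), still unmeasured, carries 1H-benzimidazol-5-yl in place of 1H-indol-5-yl (1H-benzimidazol-5-yl in place of 1H-indol-5-yl on a double-bonded chain carbon bound to an aromatic carbon and a double-bonded chain carbon). Among the measured compounds shown here, only one measured step bears on this (a 6.2-fold lower number from compound 2 to compound 3 (0.79 log units; beyond the scatter)). In that step a five-membered aromatic ring with 2 hetero atoms gave way to one with 1 hetero atom, and compound 4 brings back a ring of the former kind. A partial return towards the number of compound 2 (56 nM) is therefore expected, although a single step is thin evidence. The expected change is modest and points to a higher number (a 2.2-fold higher number from compound 3 to compound 4 (0.35 log units; beyond the scatter)). In this assay the estimated value for compound 4 is 20 nM (expected range 6 nM to 70 nM).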

Compound 4, half-maximal inhibitory concentration: 1180 nM
Estimate against measurement, compound 4: 59-fold (1.77 log units) below, and the stated range ends below it.
By their numbers in this assay, from the lowest: compound 3; then compound 2; then compound 4.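

In this assay, this position proves far less forgiving than the first pair suggested: 1H-benzimidazol-5-yl in place of 1H-indol-5-yl keeps the same number of heavy atoms and the hydrogen-bond donor, exchanges one ring carbon for nitrogen, adds a hydrogen-bond acceptor, and still gives a 130-fold higher number from compound 3 to compound 4 (2.12 log units; beyond the scatter). A five-membered aromatic ring with 2 hetero atoms does not by itself fix the number, as compound 2 also carries such a ring and the comparison shows a 21-fold higher number from compound 2 to compound 4 (1.32 log units; beyond the scatter). No measurement at hand offers a reason for this loss.

The compounds shown do not separate the effect of the added ring nitrogen from that of the whole ring. As far as these compounds go, it also remains open whether a methyl group on the ring nitrogen of 1H-indol-5-yl or a chlorine on its six-membered ring would keep the low number of compound 3 .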